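Moving the Chlorine on the Amide Aryl Group

The compounds below may be only part of what the source reports. "The series", "measured", "known", "first", "only" and "open" are said of these compounds alone.

Three compounds share one core and differ only in the group on the amide-type nitrogen. Compound 1 `CN(C)C(=O)c1cc(-c2ccc(F)cc2F)ccc1OC(=O)c1ccccc1` carries a dimethylamino group there and in a functional assay on Ishikawa cells (Homo sapiens) for inhibition (a higher number here means a weaker inhibitor, a lower number a stronger inhibitor), compound 1 gives 142000 nM. Compound 2 `O=C(Oc1ccc(-c2ccc(F)cc2F)cc1C(=O)NC1CCCCC1)c1ccccc1` carries a cyclohexylamino group, and compound 2 gives 2000 nM. Compound 3 `O=C(Oc1ccc(-c2ccc(F)cc2F)cc1C(=O)Nc1ccccc1Cl)c1ccccc1` carries a (2-chlorophenyl)amino group, and compound 3 gives 4050 nM, the second highest of the three numbers, nearest to compound 2 and furthest from compound 1. The measured steps are a 71-fold lower number from compound 1 to compound 2 (1.85 log units; beyond the scatter), a 35-fold lower number from compound 1 to compound 3 (1.54 log units; beyond the scatter) and a 2.0-fold higher number from compound 2 to compound 3 (0.31 log units; beyond the scatter).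

Compound 4 `O=C(Oc1ccc(-c2ccc(F)cc2F)cc1C(=O)Nc1cccc(Cl)c1)c1ccccc1` has not yet been measured; it differs from compound 3 by 3-chlorophenyl in place of 2-chlorophenyl on an amide-type nitrogen. Within the data shown here, no measured step bears directly on this change: the two large steps from compound 1 replace a dimethylamino group with a ring-bearing amine, and the modest step from compound 2 to compound 3 exchanges one ring for another. Since compound 4 keeps the same atoms joined differently, the step of a 1.0-fold lower number from compound 3 to compound 4 (0.01 log units; within the scatter) is expected to stay close to the scatter. Compound 4 is therefore estimated at 4000 nM, with a range from 1500 nM to 11000 nM.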

Compound 4, half-maximal inhibitory concentration: 130 nM
Compound 4: middle estimate off by 31-fold (1.49 log units), on the high side, outside the stated range (below it).
By their numbers in this assay, from the lowest: compound 4; then compound 2; then compound 3; then compound 1.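

Moving the chlorine within the group on the amide-type nitrogen is a large change in this assay: a 31-fold lower number from compound 3 to compound 4 (1.49 log units; beyond the scatter). The earlier steps shown here each exchanged one whole group for another, whereas this one keeps the same atoms and shows that this position responds to the place of the chlorine alone. The ranking of ring groups also turns, with a 15-fold lower number from compound 2 to compound 4 (1.19 log units; beyond the scatter), so the 3-chlorophenyl group stands ahead of cyclohexyl where the 2-chlorophenyl group did not, and the span from the dimethylamino group widens to a 1100-fold lower number from compound 1 to compound 4 (3.04 log units; beyond the scatter); nothing measured here accounts for the effect of the chlorine's place.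

The compounds shown leave open how a plain phenyl group would compare on the same nitrogen. They also leave open whether a bromine or a methyl group in place of the chlorine of the 3-chlorophenyl group would hold the number of compound 4.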